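Methyl Added on a Sulfonyl Chain: Expected Lipophilicity of Compound 4

The source may hold more compounds than are shown below. What is called first, only, known or untested is meant among the compounds shown, and "the series" means these compounds.

Compound 1, `CC[n+]1ccn(CCN(C)C)c1/C=N/O`, in a physicochemical assay for lipophilicity; a lower number here means a more polar compound, a higher number a more lipophilic compound: -2.71
Compound 2, `CCC[n+]1ccn(CCN(C)C)c1/C=N/O`, in this assay: -2.73
Compound 3, `CC(CS(C)(=O)=O)OCn1cc[n+](C)c1/C=N/O`, in this assay: -2.66

The three measured compounds sit close together; the values of compound 3, compound 1 and compound 2 all lie within the scatter of one another. Compound 2 differs from compound 1 by methyl in place of hydrogen on a saturated chain carbon, two bonds along the chain from an aromatic nitrogen, and that change gave a number 0.02 log units lower from compound 1 to compound 2 (within the scatter). The difference between the cores of compound 1 and compound 3 is not broken down here.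

Compound 4, `CCS(=O)(=O)CC(C)OCn1cc[n+](C)c1/C=N/O`, is not yet measured. It differs from compound 3 by methyl in place of hydrogen on a saturated chain carbon bound to a sulfonyl sulfur. This is the same kind of change as that from compound 1 to compound 2, but the place differs: there the carbon lies two bonds along the chain from an aromatic nitrogen, here it is bound to a sulfonyl sulfur. Because the earlier change gave a number 0.02 log units lower from compound 1 to compound 2 (within the scatter), compound 4 is expected to show a number 0.06 log units higher from compound 3 to compound 4 (within the scatter). For compound 4 the estimate in this assay is -2.6, with a range from -2.95 to -2.25.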

Compound 4, distribution coefficient: -2.7
Beside the measured number, compound 4's estimate is 0.10 log units above it; the range from low to high includes it.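

In this assay, methyl in place of hydrogen on a saturated chain carbon bound to a sulfonyl sulfur gave a number 0.04 log units lower from compound 3 to compound 4 (within the scatter), and the same kind of change on the other core gave a number 0.02 log units lower from compound 1 to compound 2 (within the scatter). Both pairs therefore show a methyl added on a chain with no step beyond the scatter, but two pairs that differ in both core and place do not establish a rule for other cores in this series. No evidence bears on why either step came out as it did.

The compounds shown leave open whether a longer chain, such as propylsulfonyl in place of ethylsulfonyl, would give a step beyond the scatter. They also leave open what an amine or a carboxylic acid on that chain would give.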